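Shifting a nitro group on a shared core

This account rests on a few compounds, and the source may have more. Where it says the series, first, only, none or still open, it means among the compounds named here.

Of the compounds shown here, two have been tested in a functional assay on MCF7 cells (Homo sapiens) for antiproliferative activity, read by MTT assay, with a stated time of 24 h, tested at 0.0001 ug/mL; a lower number here means a stronger effect, a higher number a weaker effect of the compound at the concentration tested. Compound 1 `O=Cc1cn(-c2ccccc2)nc1-c1ccc([N+](=O)[O-])cc1` is the smaller of the two; in this assay compound 1 gives 106%. Compound 2 `COc1cc(/C=C/C(=O)C(=Cc2cn(-c3ccccc3)nc2-c2ccc([N+](=O)[O-])cc2)C(=O)/C=C/c2ccc(O)c(OC)c2)ccc1O` contains the same core inside a much larger molecule; in this assay compound 2 gives 98%. Compound 2 has the lower of the two numbers, but the gap to compound 1 lies within the usual scatter, so the two values cannot be told apart. Both sit close to the level of untreated cells, which means that at the concentration used neither compound shows a clear effect.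

Compound 3 `COc1cc(/C=C/C(=O)C(=Cc2cn(-c3ccccc3)nc2-c2cccc([N+](=O)[O-])c2)C(=O)/C=C/c2ccc(O)c(OC)c2)ccc1O` has not yet been measured. It differs from compound 2 in one place: 3-nitrophenyl in place of 4-nitrophenyl on an aromatic carbon. The two molecules have the same atoms, joined differently. Going by the values given here, no measured pair in this set shows what such a change does, so there is no direct guide. Because compound 2 gives 98% with no effect visible, the expected step of no change at the digits printed from compound 2 to compound 3 (within the scatter) is none beyond the scatter. Compound 3 is therefore estimated at 98%, within a range from 86% to 110%.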

Compound 3, a percentage reported as activity, at one concentration (the size of the read-out at that concentration, not a potency): 99%
Beside the measured number, compound 3's estimate is 1 percentage points below it; the range from low to high includes it.
By their numbers in this assay, from the lowest: compounds 2, 3 and 1 (each within the scatter of the next).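

Going by these compounds alone, compound 3 provides the first comparison at this position: with 3-nitrophenyl in place of 4-nitrophenyl on an aromatic carbon of the five-membered ring, this assay gives a number 1 percentage points higher from compound 2 to compound 3 (within the scatter), so the two values cannot be told apart. The earlier compounds shown here could not address this, as compound 1 and compound 2 differ by far more than one place and both carry 4-nitrophenyl. Here the two molecules have the same atoms joined differently, and at the single concentration tested, this rearrangement leaves the read-out close to the level of untreated cells, with no data available to explain the result.

Going by these compounds, none of the three compounds shows a clear effect at this concentration, so it remains open whether the place of the nitro group on this phenyl ring matters under conditions where the cells do respond. On these data alone, it also remains open what an amine or a carboxylic acid carried on this phenyl ring in place of the nitro group would do to the read-out.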